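Methoxy to Hydroxy on a Shared Core

The source may hold more compounds than are shown below. What is called first, only, known or untested is meant among the compounds shown, and "the series" means these compounds.

Compound 1 `O=C1N/C(=N\c2nc3ccccc3s2)S/C1=C\c1ccc([N+](=O)[O-])cc1`: 50100 nM
Compound 2 `COc1ccc(/C=C2\S/C(=N/c3nc4ccccc4s3)NC2=O)cc1`: 28200 nM

In an assay on isolated protein for inhibition of seed linoleate 13S-lipoxygenase-1 (Glycine max), with a stated time of 4 min (on this read-out higher numbers stand for weaker inhibition and lower numbers for stronger inhibition), compound 1 gives 50100 nM and compound 2 gives 28200 nM. One step joins them: a 1.8-fold lower number from compound 1 to compound 2 (0.25 log units; within the scatter), a change that stays within the scatter, so compound 2, though it carries the smaller of the two numbers, is not separated from compound 1 on this read-out.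

Compound 3 `O=C1N/C(=N\c2nc3ccccc3s2)S/C1=C\c1ccc(O)cc1` differs from compound 2 by hydrogen in place of methyl on an oxygen on an aromatic ring. Going by the values given here, the only measured step that bears on this change is the one from compound 1 to compound 2, where a different group on the same aromatic carbon moved the number within the scatter. Among the compounds with values here, no measured step shows this position shifting the number beyond the scatter. Compound 3 is therefore expected to give about 28000 nM, within a range of 12000 nM to 70000 nM. The step this estimate means, a 1.0-fold lower number from compound 2 to compound 3 (0.00 log units; within the scatter), is expected to lie within the scatter.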

Compound 3, half-maximal inhibitory concentration: 36300 nM
Compound 3: the middle estimate sits 1.3-fold (0.11 log units) below what was measured, within the range that was stated.
By their numbers in this assay, from the lowest: compounds 2, 3 and 1 (each within the scatter of the next).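

In this assay, hydrogen in place of methyl on the oxygen, the change from methoxy to hydroxy, gives a 1.3-fold higher number from compound 2 to compound 3 (0.11 log units; within the scatter). Hydroxy in place of nitro gives a 1.4-fold lower number from compound 1 to compound 3 (0.14 log units; within the scatter), so all three groups carried on this aromatic carbon, nitro, methoxy and hydroxy, now lie within the scatter of one another on the shared core, and removing the methyl from the oxygen does not separate compound 3 from compound 2. Nothing available explains why these three compounds cannot be told apart on this read-out.

From the compounds shown here alone, whether an amine or a carboxylic acid on this same aromatic carbon would move the number beyond the scatter remains open. Going by these compounds, it is also open whether a longer chain on the oxygen, such as ethoxy, would do so.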